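The source may report more compounds than this note shows. Statements on the series, on what has been measured and on what is new or still open speak of the compounds shown alone.

Measured in a functional assay on K562 cells (Homo sapiens) for antiproliferative activity, read by CellTiter-Glo, with a stated time of 72 h; a lower number here means that less compound is needed, a higher number that more compound is needed for the effect:
- Compound 1 `CCCCCCNc1ncnc2c1ncn2[C@@H]1O[C@H](COS(N)(=O)=O)[C@@H](O)[C@H]1O`: 160 nM
- Compound 2 `CC(C)(C)CC(C)(C)Nc1ncnc2c1ncn2[C@@H]1O[C@H](COS(N)(=O)=O)[C@@H](O)[C@H]1O`: > 1000 nM (a limit)
- Compound 3 `COCCNc1ncnc2c1ncn2[C@@H]1O[C@H](COS(N)(=O)=O)[C@@H](O)[C@H]1O`: > 1000 nM (a limit)

Compound 3 has no number on this scale, only the limit > 1000 nM. It sits at the limit of > 1000 nM in this assay, at which 2 of the 3 values shown sit. Compound 4 `NS(=O)(=O)OC[C@H]1O[C@@H](n2cnc3c(NCC4CCCO4)ncnc32)[C@H](O)[C@@H]1O` is the next compound to be considered, and it differs from compound 3 in one place: oxolan-2-yl in place of methoxymethyl on a saturated chain carbon bound to a nitrogen on an aromatic ring. Cut one bond further out, the same difference reads 2-methoxyethyl to (oxolan-2-yl)methyl.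

Going by the values given here, two measured steps bear on this change, since both alter the same substituent on the nitrogen. The data show an at least 6.2-fold higher number from compound 1 to compound 3 (0.79 log units; beyond the scatter) and an at least 6.2-fold higher number from compound 1 to compound 2 (0.79 log units; beyond the scatter). Both lie beyond the scatter, but each gives only a minimum size. Among these three compounds, only the hexyl chain of compound 1 gives a number. The step between compound 2 and compound 3 cannot be read. Compound 4 keeps an oxygen in the substituent, as compound 3 does, so no clear recovery towards compound 1 is expected in this assay. The expected step is small, a step that the limit leaves unreadable from compound 3 to compound 4, and a further limit is the likeliest report. Compound 4 is estimated at 1500 nM, with an expected range of 500 nM to 5000 nM.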

Compound 4, half-maximal effective concentration: > 1000 nM
Compound 4 ended at the assay's limit; the forecaster's own chance of this, stated with the estimate: 65%; the middle value lies beyond the limit too.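

In this assay compound 4 gives > 1000 nM as a limit of the assay, not a number. The earlier compounds shown here had tested only an open 2-methoxyethyl group with an oxygen, and this result shows that the (oxolan-2-yl)methyl group, which keeps one hydrogen-bond acceptor and adds a five-membered non-aromatic ring, also gives no number; the data show an at least 6.2-fold higher number from compound 1 to compound 4 (0.79 log units; beyond the scatter) and so leave the hexyl chain of compound 1 as the only substituent here with a measured value. The steps from compound 2 and compound 3 to compound 4 cannot be read, so no gain or loss can be assigned to the ring itself, and compound 4 simply joins the group at the limit: the limit of > 1000 nM in this assay, at which 3 of the 4 values shown sit.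

The compounds shown leave open whether the ring oxygen matters, which a cyclopentylmethyl group on the same nitrogen would test directly. They also leave open whether a longer chain, such as octyl, would give a number in this assay and how it would compare with the hexyl chain.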